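Chloropyridinyl isomers: the step to compound 3

The source may report more compounds than this note shows. Statements on the series, on what has been measured and on what is new or still open speak of the compounds shown alone.

In an ADME assay on A549 cells (Homo sapiens) for cytotoxicity, read by resazurin assay, with a stated time of 48 h (on this read-out higher numbers stand for lower toxicity in this test and lower numbers for higher toxicity in this test), compound 1 (`O=C(Nc1ccc(NCc2ccncc2)cc1Cl)c1cc(Cl)ccc1O`) gives 65300 nM and compound 2 (`O=C(Nc1ccc(NCc2cccnc2Cl)cc1Cl)c1cc(Cl)ccc1O`) gives 101000 nM. Among the compounds with values here, these are the only two numbers so far, and they lie within the scatter of each other, so compound 2 cannot be separated from compound 1.

Compound 3 (`O=C(Nc1ccc(NCc2cnccc2Cl)cc1Cl)c1cc(Cl)ccc1O`) has the same atoms as compound 2, joined differently: 4-chloropyridin-3-yl in place of 2-chloropyridin-3-yl on a saturated chain carbon bound to a nitrogen on an aromatic ring.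

Within the data shown here, one measured step bears on this change: a 1.5-fold higher number from compound 1 to compound 2 (0.19 log units; within the scatter). Among the measured compounds shown here, that step also exchanges the group at this place, but no measured pair compares 2-chloropyridin-3-yl with 4-chloropyridin-3-yl directly, so the evidence is thin. For the measured compounds named here, with only that small step as a guide, no shift beyond the scatter is expected in this assay. The expected change is a 1.3-fold lower number from compound 2 to compound 3 (0.10 log units; within the scatter) and is an estimate only. For compound 3 the estimated half-maximal cytotoxic concentration is 80000 nM, with an expected range of 35000 nM to 170000 nM.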

Compound 3, half-maximal cytotoxic concentration: 126000 nM
Estimate against measurement, compound 3: 1.6-fold (0.20 log units) below; the range from low to high includes it.
By their numbers in this assay, from the lowest: compounds 1, 2 and 3 (each within the scatter of the next).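

In this assay, within the data shown here, the first direct comparison of the two isomers, 4-chloropyridin-3-yl in place of 2-chloropyridin-3-yl, gives a 1.2-fold higher number from compound 2 to compound 3 (0.10 log units; within the scatter) and so shows no readable effect of the place of the chlorine on the pyridin-3-yl ring. The comparison with the unchlorinated pyridin-4-yl group gives a 1.9-fold higher number from compound 1 to compound 3 (0.29 log units; within the scatter) in this assay, so on a saturated chain carbon bound to a nitrogen on an aromatic ring, the three pyridine groups in compounds 1, 2 and 3 cannot be separated in this test. No measured information on the compounds bears on an explanation for these results.

Whether any group at this place can move the number beyond the scatter remains open, as all three groups shown are pyridine rings, two of them carrying a chlorine. A carboxylic acid or a dimethylamino group on the pyridine ring, or a longer chain in place of the methyl link in (4-chloropyridin-3-yl)methyl, would test the limits of this position.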